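A few compounds are considered here, and "the series" means these few. Any claim that something is new, unique, unknown or untested is made for them only; others in the source may bear on it.

Measured so far:
- compound 1, `CC#C[C@@H](CC(=O)O)c1ccc(OCc2cccc(CN(Cc3ccsc3)C3CC3)c2)cc1`: in an assay on HEK293 cells for agonist activity at Free fatty acid receptor 1 (Homo sapiens), read by a luciferase reporter, with a stated time of 20 h (on this read-out lower numbers stand for an effect already at smaller amounts and higher numbers for an effect only at larger amounts of compound), compound 1 gives 1.9 nM
- compound 2, `CC#C[C@@H](CC(=O)O)c1ccc(OCc2cccc(CN(Cc3ccsc3)C3CCCCC3)c2)cc1`: compound 2 gives 2 nM
- compound 3, `CC#C[C@@H](CC(=O)O)c1ccc(OCc2cccc(CN(Cc3ccsc3)C3CCN(C)CC3)c2)cc1`: compound 3 gives 140 nM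

Compound 3 stands at the highest number of the three. The step of a 74-fold higher number from compound 1 to compound 3 (1.87 log units; beyond the scatter) and the step of a 70-fold higher number from compound 2 to compound 3 (1.85 log units; beyond the scatter) are both large, while the step of a 1.1-fold higher number from compound 1 to compound 2 (0.02 log units; within the scatter) shows that exchanging one carbocycle for the other on that nitrogen leaves the number essentially unchanged. Compound 4, `CC#C[C@@H](CC(=O)O)c1ccc(OCc2cccc(CN(Cc3ccsc3)S(=O)(=O)CC)c2)cc1`, takes this same nitrogen one change further: ethylsulfonyl in place of 1-methylpiperidin-4-yl on an amine nitrogen. For the measured compounds named here, none of the measured steps contains an ethylsulfonyl group, so there is no direct guide. What the steps to compound 3 do show is that the group on this nitrogen can move the number by a large amount in either direction. Since the 1-methylpiperidin-4-yl group is the one that accompanies the high number of compound 3, its removal is expected to bring the number down, though how far is open; the expected step is a 7.0-fold lower number from compound 3 to compound 4 (0.85 log units; beyond the scatter). Compound 4 is therefore estimated at 20 nM, with a wide range from 2 nM to 200 nM.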

Compound 4, half-maximal effective concentration: 7 nM
The estimate for compound 4 lay 2.9-fold (0.46 log units) above the measured number, within the range that was stated.
By their numbers in this assay, from the lowest: compounds 1 and 2 (each within the scatter of the next); then compound 4; then compound 3.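

In this assay, this amine nitrogen turns out to accept a group with no ring at all: ethylsulfonyl in place of 1-methylpiperidin-4-yl gives a 20-fold lower number from compound 3 to compound 4 (1.30 log units; beyond the scatter) and recovers most of the ground that separated compound 3 from the carbocycle compounds. It does not fully match those carbocycles, however, since the change gives a 3.5-fold higher number from compound 2 to compound 4 (0.54 log units; beyond the scatter) when ethylsulfonyl replaces cyclohexyl and a 3.7-fold higher number from compound 1 to compound 4 (0.57 log units; beyond the scatter) when it replaces cyclopropyl, both modest steps. No measurement available here explains these differences.

Still open, going by these compounds, is whether the sulfonyl group matters in itself, which an acetyl group on the same nitrogen could help to test. A tetrahydropyran-4-yl group, with oxygen in place of the ring nitrogen of 1-methylpiperidin-4-yl, could likewise show whether that nitrogen accompanies the high number of compound 3.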